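A Third Methoxy on the Shared Core

The source may hold more compounds than are shown below. What is called first, only, known or untested is meant among the compounds shown, and "the series" means these compounds.

Measured so far in an assay on isolated protein for inhibition of Death-associated protein kinase 3 (Homo sapiens), tested at 10 uM; a lower number here means a weaker effect, a higher number a stronger effect of the compound at the concentration tested:
compound 1 `O=C1OC(c2ccc(Cl)c([N+](=O)[O-])c2)=N/C1=C\c1cccnc1` gives 100%
compound 2 `COc1ccc(C2=N/C(=C\c3cccnc3)C(=O)O2)cc1Br` gives 32%
compound 3 `COc1ccc(C2=N/C(=C\c3cccnc3)C(=O)O2)cc1OC` gives 36%

Compound 3 stands second highest of the three numbers. Its nearest neighbour is compound 2, and the step of a number 4 percentage points higher from compound 2 to compound 3 (within the scatter) is within the scatter, so the two cannot be told apart. Compound 1 lies far higher, beyond the scatter. Compound 4 `COc1cc(C2=N/C(=C\c3cccnc3)C(=O)O2)cc(OC)c1OC` differs from compound 3 by methoxy in place of hydrogen on an aromatic carbon. Among the compounds with values here, the only measured step with a methoxy entering is the one from bromo, a number 4 percentage points higher from compound 2 to compound 3 (within the scatter), and it barely moved the number. Within the data shown here, no measured step shows methoxy in place of hydrogen, so this change is essentially untested. The expected step of a number 1 percentage points lower from compound 3 to compound 4 (within the scatter) is therefore none beyond the scatter. Compound 4 is estimated at 35%, with a range from 10% to 65%.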

Compound 4, a percentage reported as inhibition, at one concentration (the size of the read-out at that concentration, not a potency): 33%
The estimate for compound 4 lay 2 percentage points above the measured number, within the range that was stated.
By their numbers in this assay, from the lowest: compounds 2, 4 and 3 (each within the scatter of the next); then compound 1.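

The only measured case of methoxy in place of hydrogen on an aromatic carbon gives a number 3 percentage points lower from compound 3 to compound 4 (within the scatter) in this assay and so leaves compound 3 and compound 4 impossible to tell apart. At this position, ortho to a methoxy group, the added methoxy therefore keeps the read-out within the scatter. No available measurement explains this result.

Going by these compounds, whether an amine or a carboxylic acid at this position would also stay within the scatter remains open. So does the effect of a longer chain, such as propoxy, there.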